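The compounds below may be only part of what the source reports. "The series", "measured", "known", "first", "only" and "open" are said of these compounds alone.

- compound 1 `CNC(=O)/C=C/CNCCOc1ccc(Oc2c(-c3ccc(F)cc3)sc3cc(O)ccc23)cc1`: 15500 nM
- compound 2 `O=C(/C=C/CNCCOc1ccc(Oc2c(-c3ccc(F)cc3)sc3cc(O)ccc23)cc1)N1CCC1`: 6560 nM

In a functional assay on Ishikawa cells (Homo sapiens) for antiproliferative activity, read by CCK-8 assay, with a stated time of 48 h (on this read-out higher numbers stand for weaker inhibition and lower numbers for stronger inhibition), compound 2 holds the lower of the two numbers at 6560 nM. Compound 3 `C=CC(=O)N1CC(Oc2ccc(Oc3c(-c4ccc(F)cc4)sc4cc(O)ccc34)cc2)C1` differs from it on an oxygen on an aromatic ring: 1-(vinylcarbonyl)azetidin-3-yl in place of 2-((3-((azetidin-1-yl)carbonyl)prop-2-en-1-yl)amino)ethyl on an oxygen on an aromatic ring. Among the measured compounds shown here, only one measured step bears on this change: a 2.4-fold lower number from compound 1 to compound 2 (0.37 log units; beyond the scatter). That modest step replaced far less of the molecule, so it gives no firm direction here. The expected result is therefore no clear shift beyond the scatter, an estimated 1.3-fold lower number from compound 2 to compound 3 (0.12 log units; within the scatter). The estimated value for compound 3 is 5000 nM, with an expected range from 900 nM to 25000 nM.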

Compound 3, half-maximal inhibitory concentration: 12300 nM
Estimate against measurement, compound 3: 2.5-fold (0.39 log units) below; the range from low to high includes it.
By their numbers in this assay, from the lowest: compounds 2, 3 and 1 (each within the scatter of the next, the first and the last beyond it).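

In this assay, replacing the whole chain on the oxygen with 1-(vinylcarbonyl)azetidin-3-yl gives a 1.9-fold higher number from compound 2 to compound 3 (0.27 log units; within the scatter) and, measured against the methylamino relative, a 1.3-fold lower number from compound 1 to compound 3 (0.10 log units; within the scatter). This position therefore accepts a group with fewer heavy atoms and 0 hydrogen-bond donors, and the long chain with its amine is not needed to keep activity in this range of numbers. Nothing measured here accounts for this result. From the compounds shown here alone, what a propanoyl group or a simple amine would do in place of the vinylcarbonyl group stays open.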